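This account rests on a few compounds, and the source may have more. Where it says the series, first, only, none or still open, it means among the compounds named here.

Compound 1 `Cc1ccc(-c2ccc(C(=O)N=C(N)N)cc2S(C)(=O)=O)cc1` gives 100 nM in a functional assay for inhibition of sodium/hydrogen exchanger (Oryctolagus cuniculus); a higher number here means a weaker inhibitor, a lower number a stronger inhibitor.
Compound 2 `Cc1cc(-c2ccc(Cl)cc2Cl)c(S(C)(=O)=O)cc1C(=O)N=C(N)N` gives 42 nM in this assay.
Compound 3 `Cc1cc(-c2cc(C(F)(F)F)cc(C(F)(F)F)c2)c(S(C)(=O)=O)cc1C(=O)N=C(N)N` gives 2800 nM in this assay.

Among these three, compound 2 stands at the lowest number in this assay, and its steps to compound 1 and to compound 3 are both beyond the usual scatter, so it is the strongest inhibitor of the set. Compound 1 is the nearest to it, while compound 3 lies far above both.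

Compound 4 `Cc1cc(O)c(S(C)(=O)=O)cc1C(=O)N=C(N)N` has not yet been measured. It differs from compound 2 in one place: hydroxy in place of 2,4-dichlorophenyl on an aromatic carbon. The whole 2,4-dichlorophenyl ring is gone and a single hydroxy takes its place on the shared core.

For the measured compounds named here, no measured pair in this set carries so large a change, so the expectation rests on the weight of what is removed. With compound 2 at 42 nM as the starting point, a clear rise in the number is expected, well beyond the scatter. The step from compound 2 to compound 4 is estimated as a 36-fold higher number from compound 2 to compound 4 (1.55 log units; beyond the scatter). For compound 4 the estimate in this assay is 1500 nM, within a range from 200 nM to 10000 nM.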

Compound 4, half-maximal inhibitory concentration: 220 nM
For compound 4 the middle estimate is 6.8-fold (0.83 log units) above the measured one; the range from low to high includes it.
By their numbers in this assay, from the lowest: compound 2; then compound 1; then compound 4; then compound 3.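

In this assay, hydroxy in place of 2,4-dichlorophenyl, on the aromatic carbon ortho to a methylsulfonyl group, gives a 5.2-fold higher number from compound 2 to compound 4 (0.72 log units; beyond the scatter), a modest step for the removal of a whole ring. This position therefore does not depend on an aromatic ring for inhibition to persist: with only a hydroxy there, compound 4 still gives 220 nM. Nothing measured here accounts for the size of this step.

The compounds shown leave open how much of the step belongs to losing the ring and how much to the hydroxy itself, which a methoxy, an amine or plain hydrogen on this carbon would help separate. They also leave open where a ring-free group such as a longer chain or a carboxylic acid would fall in this assay.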